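Hydroxy-oxindole tetrazoles: chain length and halogen swap

The compounds below may be only part of what the source reports. "The series", "measured", "known", "first", "only" and "open" are said of these compounds alone.

Measured so far in a functional assay on BT-549 cells (Homo sapiens) for antiproliferative activity, read by MTT assay, with a stated time of 48 h; on this read-out lower numbers stand for stronger inhibition and higher numbers for weaker inhibition:
- Compound 1 `CN1C(=O)C(O)(Cc2nnn[nH]2)c2cc(Cl)ccc21`. The value for compound 1 is a limit, > 100000 nM.
- Compound 2 `CCN1C(=O)C(O)(Cc2nnn[nH]2)c2cc(Cl)ccc21` gives 85400 nM.
- Compound 3 `CN1C(=O)C(O)(Cc2nnn[nH]2)c2cc(Br)ccc21`. The value for compound 3 is a limit, > 100000 nM.

Two of the three values sit at the limit (the limit of > 100000 nM in this assay, at which 2 of the 3 values shown sit), so little of the series is resolved. For the measured compounds named here, the one measured change is methyl in place of hydrogen on a saturated chain carbon bound to an amide-type nitrogen in a ring, and it gave an at least 1.1-fold lower number from compound 1 to compound 2 (0.06 log units; that floor lies within the scatter). The two cores differ as bromo in place of chloro on an aromatic carbon; the two limits leave that step unreadable, a step that the two limits leave unreadable from compound 1 to compound 3.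

Compound 4 `CCN1C(=O)C(O)(Cc2nnn[nH]2)c2cc(Br)ccc21` is not yet measured. It carries the same kind of change as compound 2 carries on the core of compound 1, namely (methyl in place of hydrogen on a saturated chain carbon bound to an amide-type nitrogen in a ring). The starting point for compound 3 is itself a limit, > 100000 nM. Because the step of an at least 1.1-fold lower number from compound 1 to compound 2 (0.06 log units; that floor lies within the scatter) is only a floor that lies within the scatter, the expectation for compound 4 rests on thin ground: the change is expected to leave the number close to where compound 3 stands, with the chance that this assay again reports only a limit. The step from compound 3 to compound 4 is estimated as a number no higher from compound 3 to compound 4 (the limit leaves the size open). Compound 4 is expected to give about 100000 nM in this assay, estimated between 50000 nM and 200000 nM.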

Compound 4, half-maximal inhibitory concentration: > 100000 nM
Compound 4: no number, only a limit; the forecaster's own chance of this, stated with the estimate: 55%; the middle value sits exactly at the limit.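

In this assay compound 4 gives only a limit, > 100000 nM, and not a number. For the compounds shown here, the steps that end in a limit on both sides cannot be read, so the data neither confirm nor exclude that methyl in place of hydrogen on a saturated chain carbon bound to an amide-type nitrogen in a ring carries over from the core of compound 1 to the core of compound 3: the limit of > 100000 nM in this assay, at which 3 of the 4 values shown sit. The one readable new step, for bromo in place of chloro on an aromatic carbon, is an at least 1.1-fold higher number from compound 2 to compound 4 (0.06 log units; that floor lies within the scatter), so it shows no effect of the halogen swap on the ethyl-bearing core and gives no measured size for the change on either core.

Going by these compounds alone, compound 2 remains the only compound with a number, 85400 nM, so the series offers a single measured point and no trend can be drawn from it. Open, as far as these compounds go, is whether a longer chain such as propyl, or a chain ending in an amine or a carboxylic acid, in place of methyl or ethyl would give a number clear of the limit on either core.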